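A few compounds are considered here, and "the series" means these few. Any claim that something is new, unique, unknown or untested is made for them only; others in the source may bear on it.

Compound 1 `CC(C)[C@H](NC(=O)COc1cccc2ccccc12)C(=O)N[C@@H](CC(=O)O)C(=O)COc1cccc2ccccc12` is the anchor here. In a functional assay with Homo sapiens as the target (a higher number here means a weaker inhibitor, a lower number a stronger inhibitor), compound 1 gives 19000 nM, the lower of the two numbers recorded so far and thus the stronger of the two measured inhibitors. Compound 2 `CC(C)[C@H](NC(=O)COc1cccc2ccccc12)C(=O)N[C@@H](CC(=O)O)C(=O)COc1ccc(-c2ccccc2)cc1` differs only at one end, and in this assay compound 2 gives 38700 nM; the step of a 2.0-fold higher number from compound 1 to compound 2 (0.31 log units; beyond the scatter) was modest but beyond the scatter. Compound 3 `CC(C)[C@H](NC(=O)COc1cccc2ccccc12)C(=O)N[C@@H](CC(=O)O)C(=O)COc1c(F)cccc1F` has not been measured. It differs from compound 1 in one place: 2,6-difluorophenyl in place of naphthalen-1-yl on an oxygen on a saturated carbon. Among the measured compounds shown here, the only step that bears on this change is the one from compound 1 to compound 2, which swapped the same group at the same oxygen for another aromatic group and weakened inhibition modestly. That is thin evidence, and the entering group is a different kind of ring, so for compound 3 the estimated step of a 1.3-fold higher number from compound 1 to compound 3 (0.12 log units; within the scatter) is small, with a wide range. Compound 3 is expected to give 25000 nM in this assay, between 9000 nM and 70000 nM.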

Compound 3, half-maximal inhibitory concentration: > 100000 nM
Compound 3 was reported as a limit; the forecaster's own chance of this, stated with the estimate: 15%; at least 4.0-fold (0.60 log units) between middle value and limit.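

The reading for compound 3 is a limit of the assay and not a number: the limit of > 100000 nM in this assay, at which 1 of the 3 values shown sits. Even so, the change on this oxygen can be read as an at least 5.2-fold higher number from compound 1 to compound 3 (0.72 log units; beyond the scatter), and the swap away from 4-phenylphenyl reads as an at least 2.5-fold higher number from compound 2 to compound 3 (0.41 log units; beyond the scatter). This position therefore does not accept every aromatic group equally: naphthalen-1-yl and 4-phenylphenyl both gave numbers, whereas 2,6-difluorophenyl, with its one aromatic ring, reaches the limit.

The compounds shown do not separate the loss of the second ring in naphthalen-1-yl from the arrival of the two fluorines, and a plain phenyl group on this oxygen would be the comparison that pulls those two changes apart. They also leave open how far beyond its limit compound 3 lies.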